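The source may report more compounds than this note shows. Statements on the series, on what has been measured and on what is new or still open speak of the compounds shown alone.

Values in a functional assay on HL-60 cells (Homo sapiens) for inhibition, read by resazurin assay, with a stated time of 72 h; on this read-out higher numbers stand for weaker inhibition and lower numbers for stronger inhibition:
- compound 1 `CCOc1ccc(C2C(C3CC3)C(=O)N2c2cc(OC)c(OC)c(OC)c2)cc1`: 201 nM
- compound 2 `COc1ccc(C2C(C3CC3)C(=O)N2c2cc(OC)c(OC)c(OC)c2)cc1`: 156 nM
- compound 3 `COc1cc(N2C(=O)C(O)C2c2ccc(SC)cc2)cc(OC)c1OC`: 15 nM

Compound 1 sits at the upper end of these three numbers, level with compound 2 within the scatter, while compound 3 lies clearly lower. The next compound to read is compound 4 `C=CC1C(=O)N(c2cc(OC)c(OC)c(OC)c2)C1c1ccc(OCC)cc1`, which keeps the core of compound 1 and its 4-ethoxyphenyl group. The change is vinyl in place of cyclopropyl on a saturated ring carbon.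

Within the data shown here, no measured step covers this change. Among the measured compounds shown here, the only step available is a 1.3-fold lower number from compound 1 to compound 2 (0.11 log units; within the scatter), and it concerns the chain on the aromatic oxygen, so it shows only that one small edit elsewhere on the compound left this assay within the scatter. For the measured compounds named here, compound 3, at 15 nM, shows that much lower numbers occur, but it gives no step for this swap and supports only a slight lean downward. No shift beyond the scatter is therefore expected. The expected step is a 1.8-fold lower number from compound 1 to compound 4 (0.26 log units; within the scatter). In this assay the estimate for compound 4 is 110 nM, with an expected range from 25 nM to 350 nM.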

Compound 4, half-maximal inhibitory concentration: 35 nM
Beside the measured number, compound 4's estimate is 3.1-fold (0.50 log units) above it; the measured number falls inside the stated range.
By their numbers in this assay, from the lowest: compound 3; then compound 4; then compounds 2 and 1 (each within the scatter of the next).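

This position on the saturated ring carbon of the four-membered ring responds in this assay: the change to vinyl in place of cyclopropyl gives a 5.7-fold lower number from compound 1 to compound 4 (0.76 log units; beyond the scatter) and is the first step shown here to lie beyond the scatter. Among these compounds, the only earlier step, a 1.3-fold lower number from compound 1 to compound 2 (0.11 log units; within the scatter) at the chain on the aromatic oxygen, stayed within the scatter, so this ring carbon is the one place so far where a single edit clearly shifts the number, here towards stronger inhibition. This reading rests on one pair of compounds, and no measurement shown offers an explanation for the step.

Still open, on these data alone, is whether the step carries over when the aromatic oxygen bears the methyl group of compound 2 in place of the ethyl group of compound 4. Also open, as far as these compounds go, is whether the shift follows from the double bond or from the loss of the three-membered ring, a question that an ethyl group at this position would help to separate, while an allyl group or an amine there would show how far the position tolerates other substituents.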